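The compounds below may be only part of what the source reports. "The series", "measured", "known", "first", "only" and "open" are said of these compounds alone.

Measured so far, in a functional assay on L1210 cells (Mus musculus); a lower number here means a stronger inhibitor, a higher number a weaker inhibitor:
Compound 1, `CCC#Cc1cn(C2O[C@H](CO)[C@@H](O)[C@@H]2O)c(=O)[nH]c1=O`: a limit only, > 1000 ug/mL.
Compound 2, `CCC#Cc1cn([C@H]2C[C@H](O)[C@@H](CO)O2)c(=O)[nH]c1=O`: a limit only, > 1000 ug/mL.
Compound 3, `Cc1ccc(S(=O)(=O)OCCC#Cc2cn([C@H]3C[C@H](O)[C@@H](CO)O3)c(=O)[nH]c2=O)cc1`: a limit only, > 200 ug/mL.

Among the measured compounds shown here, compound 2 stands nowhere in particular on these numbers: its value is a limit, and every value shown in this assay is likewise a limit, two of them at the limit of > 1000 ug/mL in this assay, at which 2 of the 3 values shown sit, and one at the limit of > 200 ug/mL in this assay, at which 1 of the 3 values shown sits, so no order among compounds 1, 2 and 3 can be read and no measured step between them exists.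

Compound 4, `O=c1[nH]c(=O)n([C@H]2C[C@H](O)[C@@H](CO)O2)cc1C#CCO`, differs from compound 2 by hydroxy in place of methyl on a saturated chain carbon bound to a triple-bonded carbon. For the measured compounds named here, with no measured step anywhere, the step from compound 2 to compound 4 is expected to stay within the scatter, in no direction, and compound 4 is expected to sit at the same limit because compound 2 itself gives only > 1000 ug/mL. The estimate for compound 4 in this assay is 1000 ug/mL, between 300 ug/mL and 3000 ug/mL, with the expected step of a number no higher from compound 2 to compound 4 (the limit leaves the size open) read as none beyond scatter; most likely the assay again reports only a limit for compound 4.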

Compound 4, concentration for 50% inhibition: > 1000 ug/mL
Compound 4 ended at the assay's limit; the forecaster's own chance of this, stated with the estimate: 80%; the middle value lies on the limit itself.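

Among the compounds shown here, compound 2 and compound 4 each give only a limit in this assay, so no step between them can be read: the limit of > 1000 ug/mL in this assay, at which 3 of the 4 values shown sit.

The compounds shown leave open whether hydroxy in place of methyl on a saturated chain carbon bound to a triple-bonded carbon changes inhibition at all.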